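A few compounds are considered here, and "the series" means these few. Any claim that something is new, unique, unknown or untested is made for them only; others in the source may bear on it.

In a functional assay on microsomes for inhibition, with a stated time of 1 h (on this read-out higher numbers stand for weaker inhibition and lower numbers for stronger inhibition), compound 2 `Cn1c(NN)nc(-c2ccco2)c(C#N)c1=O` gives 78 ug/mL, and compound 1 `CSc1nc(-c2ccco2)c(C#N)c(=O)n1C` gives 90 ug/mL. Among the compounds with values here, the one change between them, (methylsulfanyl in place of aminoamino on an aromatic carbon), made a step of a 1.2-fold higher number from compound 2 to compound 1 (0.06 log units; within the scatter). Compound 3 `Cn1c(NN)nc(-c2ccccc2Cl)c(C#N)c1=O` carries a different core; the difference between the two cores is not broken down here. In this assay compound 3 gives 57 ug/mL. Compound 4 `CSc1nc(-c2ccccc2Cl)c(C#N)c(=O)n1C` is not yet measured. It differs from compound 3 by methylsulfanyl in place of aminoamino on an aromatic carbon. Within the data shown here, this is the same kind of change as the one from compound 2 to compound 1, though around the place one core holds a furan-2-yl group (5 heavy atoms) and the other a group of 7 heavy atoms. Because the earlier step of a 1.2-fold higher number from compound 2 to compound 1 (0.06 log units; within the scatter) stayed within the scatter, the step expected for compound 4 is a 1.2-fold higher number from compound 3 to compound 4 (0.09 log units; within the scatter), giving an estimate of 70 ug/mL, likely between 40 ug/mL and 120 ug/mL.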

Compound 4, half-maximal inhibitory concentration: 72 ug/mL
Estimate against measurement, compound 4: 1.0-fold (0.01 log units) below, within the range that was stated.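

In this assay, methylsulfanyl in place of aminoamino gives a 1.3-fold higher number from compound 3 to compound 4 (0.10 log units; within the scatter), so on this core too the change stays within the usual scatter. Set beside the earlier step, the change carries across the two cores with no visible difference: the same change on two cores in this assay, a 1.2-fold higher number (0.06 log units; within the scatter) from compound 2 to compound 1 and a 1.3-fold higher number (0.10 log units; within the scatter) from compound 3 to compound 4, 1.1-fold (0.04 log units) apart, within the scatter of two such steps. Within the data shown here, neither step rises above the scatter, so the pair shows only that this swap does little on these two cores, not that it would do as little on every core.

The compounds shown leave open whether another group at this place, such as a simple amine, a methoxy group or a longer thioether chain, would move the read-out beyond the scatter. They also leave open how the swap behaves on cores carrying other groups in place of furan-2-yl.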